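The compounds below may be only part of what the source reports. "The series", "measured", "known", "first", "only" and "open" are said of these compounds alone.

Compound 1 `COc1cc(-c2cc(/C=C/C(=O)c3ccc(Cl)c(Cl)c3)[nH]n2)cc(OC)c1OC` gives 54600 nM in a functional assay on RXF 393 cells (Homo sapiens) for inhibition, read by sulforhodamine B assay, with a stated time of 48 h; a higher number here means that more compound is tolerated, a lower number that less compound is tolerated.
Compound 2 `COc1ccc(-c2cc(/C=C/C(=O)c3cc(OC)c(OC)c(OC)c3)[nH]n2)cc1OC` gives 6510 nM in this assay.
Compound 3 `COc1ccc(C(=O)/C=C/c2cc(-c3cc(OC)c(OC)c(OC)c3)n[nH]2)cc1OC` gives 5230 nM in this assay.

Among these three, compound 3 has the lowest number. Its nearest neighbour is compound 2, whose value lies within the usual scatter of it, so the two cannot be told apart. Among the measured compounds shown here, compound 1 is the furthest away: the only measured step that involves compound 3, a 10-fold lower number from compound 1 to compound 3 (1.02 log units; beyond the scatter), came with 3,4-dimethoxyphenyl in place of 3,4-dichlorophenyl on a carbonyl carbon.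

Compound 4 `COc1cc(C(=O)/C=C/c2cc(-c3cc(OC)c(OC)c(OC)c3)n[nH]2)cc(OC)c1OC` is not yet measured. It differs from compound 3 by methoxy in place of hydrogen on an aromatic carbon.

For the measured compounds named here, no measured step matches this change. Going by the values given here, the one step that exists, from compound 1 to compound 3, concerns a different exchange, and compound 2 and compound 3 are not related by a single change of this kind. With so little to go on, compound 4 is expected to stay close to compound 3, with a step of a 1.2-fold lower number from compound 3 to compound 4 (0.07 log units; within the scatter) that should not be beyond the scatter. Compound 4 is therefore estimated at 4500 nM, within a range from 1500 nM to 14000 nM.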

Compound 4, concentration lethal to 50% of the cells: 5680 nM
Compound 4: middle estimate off by 1.3-fold (0.10 log units), on the low side, and the stated range covers the measured number.
By their numbers in this assay, from the lowest: compounds 3, 4 and 2 (each within the scatter of the next); then compound 1.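

The step of a 1.1-fold higher number from compound 3 to compound 4 (0.04 log units; within the scatter) shows that in this assay a methoxy in place of hydrogen on this aromatic carbon, ortho to a methoxy group, gives a number the scatter cannot separate from the one before it. The same kind of exchange on the other six-membered aromatic ring gives the step of a 1.1-fold lower number from compound 2 to compound 4 (0.06 log units; within the scatter) and cannot be read as a change either, so at these two places the extra methoxy makes no measurable difference, unlike the much larger step a 10-fold lower number from compound 1 to compound 3 (1.02 log units; beyond the scatter) that came with 3,4-dimethoxyphenyl in place of 3,4-dichlorophenyl. Nothing measured here speaks to the reason for this flat result.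

From the compounds shown here alone, what stays open is whether this place accepts only a methoxy or other groups as well: a hydroxy group, an amine or a longer chain such as ethoxy might give a number beyond the scatter of compound 3. Going by these compounds, it is also open whether the extra methoxy would stay just as silent on a compound that keeps the 3,4-dichlorophenyl of compound 1.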